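Working notes on a chloro-for-methyl swap across two cores

The compounds below may be only part of what the source reports. "The series", "measured", "known", "first", "only" and "open" are said of these compounds alone.

Measured so far, in a functional assay on HeLa cells (Homo sapiens) for cytotoxicity, read by MTT assay, with a stated time of 48 h; on this read-out higher numbers stand for weaker inhibition and lower numbers for stronger inhibition:
compound 1 `CCOC(=O)c1c(-c2c(Cl)c3ccccc3oc2=O)nn(-c2cccc(C)c2)c1C(=O)OCC`: 30000 nM
compound 2 `CCOC(=O)c1c(-c2c(Cl)c3ccccc3oc2=O)nn(-c2cccc(Cl)c2)c1C(=O)OCC`: 40000 nM
compound 3 `CCOC(=O)c1c(-c2cc3ccc(OC)cc3oc2=O)nn(-c2cccc(C)c2)c1C(=O)OCC`: 35000 nM

Compound 1 and compound 2 share one core and differ by chloro in place of methyl on an aromatic carbon; this step gave a 1.3-fold higher number from compound 1 to compound 2 (0.12 log units; within the scatter). Compound 3 carries a different core; the difference between the two cores is not broken down here. Compound 4 `CCOC(=O)c1c(-c2cc3ccc(OC)cc3oc2=O)nn(-c2cccc(Cl)c2)c1C(=O)OCC` is not yet measured and differs from compound 3 by chloro in place of methyl on an aromatic carbon, the same change as that made between compound 1 and compound 2, at a place described in the same words. The expected step in this assay is a 1.3-fold higher number from compound 3 to compound 4 (0.11 log units; within the scatter), because a 1.3-fold higher number from compound 1 to compound 2 (0.12 log units; within the scatter) shows a step within the scatter for the same change on the other core. Compound 4 is therefore expected to give 45000 nM, with a range from 25000 nM to 80000 nM.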

Compound 4, half-maximal inhibitory concentration: 205000 nM
Beside the measured number, compound 4's estimate is 4.6-fold (0.66 log units) below it, outside the stated range (above it).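

In this assay, chloro in place of methyl on the aromatic carbon gives a 5.9-fold higher number from compound 3 to compound 4 (0.77 log units; beyond the scatter). Set beside the earlier step, the same change does not carry over in size from one core to the other: the same change on two cores in this assay, a 1.3-fold higher number (0.12 log units; within the scatter) from compound 1 to compound 2 and a 5.9-fold higher number (0.77 log units; beyond the scatter) from compound 3 to compound 4, 4.4-fold (0.64 log units) apart, beyond the scatter of two such steps. Going by these compounds alone, with one pair on each core, this shows only that the step differs between these two cores; it does not show which feature of the cores goes with the difference, or how any other change would carry over.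

Open, going by these compounds, is whether the gap between the cores also appears with other groups at this place, such as an amine or a carboxylic acid in place of the methyl. Also open, on these data alone, is how the same swap behaves on any further core.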